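The compounds below may be only part of what the source reports. "The series", "measured", "known", "first", "only" and "open" are said of these compounds alone.

Working notes on the series. All four compounds share one core with a hydrazone arm ending in a substituted phenyl ring: compound 1 `O=C(CCc1nc2ccccc2c(=O)[nH]1)N/N=C/c1ccc(Cl)cc1`, compound 2 `O=C(CCCc1nc2ccccc2c(=O)[nH]1)N/N=C/c1ccc([N+](=O)[O-])cc1`, compound 3 `COc1cc(/C=N/NC(=O)CCc2nc3ccccc3c(=O)[nH]2)cc(OC)c1OC` and the still unmeasured compound 4 `O=C(CCCc1nc2ccccc2c(=O)[nH]1)N/N=C/c1ccc(O)cc1`.

In a physicochemical assay, read by spectrophotometry, with a stated time of 30 min (a higher number here means a weaker inhibitor, a lower number a stronger inhibitor), compound 1 gives 381000000 nM, compound 2 gives 316000000 nM and compound 3 gives 85000000 nM. Compound 2 stands second highest of the three numbers. Its gap to compound 1 lies within the scatter, so no order between these two can be read. Compound 3 sits lower by a margin beyond the scatter.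

Compound 4 differs from compound 2 by hydroxy in place of nitro on an aromatic carbon. Within the data shown here, no measured pair isolates this change, so its size cannot be taken from the data. The step expected in this assay is a 1.3-fold lower number from compound 2 to compound 4 (0.10 log units; within the scatter), small and toward a lower number, hardly beyond the scatter. Compound 4 is therefore estimated at 250000000 nM, with a range from 80000000 nM to 800000000 nM.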

Compound 4, half-maximal inhibitory concentration: 214000000 nM
For compound 4 the middle estimate is 1.2-fold (0.07 log units) above the measured one; measured number inside the range.
By their numbers in this assay, from the lowest: compound 3; then compounds 4, 2 and 1 (each within the scatter of the next).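

Among these compounds, replacing 4-nitrophenyl with 4-hydroxyphenyl gives the first measured pair that differs in one place only, and in this assay this change gives a 1.5-fold lower number from compound 2 to compound 4 (0.17 log units; within the scatter) with the rest of the molecule held constant. On this aromatic carbon, para to a large group, the read-out therefore does not separate nitro from hydroxy, even though the two differ in heavy atoms and hydrogen-bond donors. No supporting measurement bears on why the step has this size.

Open, as far as these compounds go, is whether an amine or a carboxylic acid at this position would also stay within the scatter of compound 2. Also open, from the compounds shown here alone, is what a longer chain would do, and compound 3 differs from compound 2 in more than one place, so its lower number cannot be assigned to any single change.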